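The compounds below may be only part of what the source reports. "The series", "measured", "known", "first", "only" and "open" are said of these compounds alone.

Measured compounds:
- compound 1, `CCC(CC)[C@@H]1C(=O)N[C@H](C2Cc3ccccc3C2)C(=O)N1[C@@H](C(=O)N1CCOCC1)c1ccc(C)nc1`, in an assay on isolated protein for displacement of a labelled ligand from Oxytocin receptor (Homo sapiens) (a lower number here means a stronger inhibitor, a higher number a weaker inhibitor), compound 1 gives 0.0251 nM
- compound 2, `Cc1ccc([C@H](C(=O)N(C)C)N2C(=O)[C@@H](C3Cc4ccccc4C3)NC(=O)[C@H]2CC(C)C)cn1`, compound 2 gives 1.59 nM
- compound 3, `CC[C@H](C)[C@@H]1C(=O)N[C@H](C2Cc3ccccc3C2)C(=O)N1[C@@H](C(=O)N(C)C)c1ccc(C)nc1C`, compound 3 gives 0.0794 nM

Compound 2 has the highest number of the three in this assay: the gaps to compound 3 and to compound 1 are both beyond the scatter, so compound 2 is the weakest inhibitor shown. Compounds 1 and 3 each differ from compound 2 in several places at once, so none of these gaps isolates a single change.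

Compound 4, `Cc1ccc([C@H](C(=O)N2CCCC2)N2C(=O)[C@@H](C3Cc4ccccc4C3)NC(=O)[C@H]2CC(C)C)cn1`, is the untested partner of compound 2. The change is pyrrolidin-1-yl in place of dimethylamino on a carbonyl carbon. Among the measured compounds shown here, no pair of measured compounds separates this change from others, so there is no measured step to lean on. The two cyclic amides in compound 1 and the dimethylamide in compound 2 sit in otherwise different molecules and say nothing on their own about this change. A small move toward a lower number is expected, a 2.0-fold lower number from compound 2 to compound 4 (0.30 log units; within the scatter), within or just beyond the scatter. For compound 4 the expected value in this assay is 0.8 nM, with a range of 0.2 nM to 3.2 nM.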

Compound 4, inhibition constant in the Oxytocin receptor assay: 0.501 nM
Compound 4: middle estimate off by 1.6-fold (0.20 log units), on the high side; the measured number falls inside the stated range.
By their numbers in the Oxytocin receptor assay, from the lowest: compound 1; then compound 3; then compound 4; then compound 2.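

Among the compounds shown here, in the Oxytocin receptor assay, pyrrolidin-1-yl in place of dimethylamino on a carbonyl carbon gives a 3.2-fold lower number from compound 2 to compound 4 (0.50 log units; beyond the scatter), the first single change in the set, and it shows that this group alone moves the number beyond the scatter. In a physicochemical assay for solubility, read by HPLC (on this read-out higher numbers stand for higher solubility and lower numbers for lower solubility), the same step cannot be read, and compound 2 gives > 236 ug/mL, which is a limit of the assay and not a number: the limit of > 236 ug/mL in the physicochemical assay, at which 1 of the 2 values shown sits. In the physicochemical assay compound 4 gives 241 ug/mL, so no change in solubility can be stated for this swap.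

As far as these compounds go, whether piperidin-1-yl or diethylamino on the same carbonyl carbon would extend or reverse the step remains open. Also open, from the compounds shown here alone, is whether the change from dimethylamino to pyrrolidin-1-yl gives a similar step on the more potent compound 3, which carries dimethylamino at this place.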